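This account rests on a few compounds, and the source may have more. Where it says the series, first, only, none or still open, it means among the compounds named here.

Three compounds built on a closely related core have been followed in an ADME assay on the whole organism (plasma) for pharmacokinetics, with Rhesus monkey (Macaca mulatta) as the target, read by LC-MS, at a dose of 1 mg/kg by the oral route; on this read-out lower numbers stand for lower exposure and higher numbers for higher exposure at the dose given. Compound 1 `COc1ccc2nc(COc3ccc(CC4(O)SC(=O)NC4=O)cc3)n(C)c2c1` gives 7.33 ng.h/mL, compound 2 `O=C1NC(=O)C(Cc2ccc(OCc3nc4ccc(O)cc4[nH]3)cc2)S1` gives 85.4 ng.h/mL, and compound 3 `Cn1c(COc2ccc(CC3SC(=O)NC3=O)cc2)nc2ccc(O)cc21` gives 310 ng.h/mL. Compound 3 therefore has the highest number of the three, clear of the scatter from both others. The next structure is compound 4 `Cn1c(COc2ccc(CC3SC(=O)NC3=O)cc2)nc2ccc(OS(=O)(=O)O)cc21`, which differs from compound 3 as follows: sulfo in place of hydrogen on an oxygen on an aromatic ring.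

For the measured compounds named here, only one measured step is available for comparison: a 3.6-fold higher number from compound 2 to compound 3 (0.56 log units; beyond the scatter), a modest rise seen with methyl in place of hydrogen on an aromatic nitrogen. That change is of another kind and in a different place, so it offers a sense of scale and no direction. Going by the values given here, no measured compound carries sulfo. The estimated shift, a 1.3-fold higher number from compound 3 to compound 4 (0.11 log units; within the scatter), is thus an expectation of no clear change, held with wide uncertainty. For compound 4 the estimated value is 400 ng.h/mL, with an expected range from 50 ng.h/mL to 3000 ng.h/mL.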

Compound 4, area under the concentration-time curve: 200 ng.h/mL
Compound 4: middle estimate off by 2.0-fold (0.30 log units), on the high side; the measured number falls inside the stated range.
By their numbers in this assay, from the lowest: compound 1; then compound 2; then compounds 4 and 3 (each within the scatter of the next).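

In this assay, putting sulfo on this oxygen gives a 1.6-fold lower number from compound 3 to compound 4 (0.19 log units; within the scatter). The oxygen on the aromatic ring can therefore carry sulfo, with its four extra heavy atoms, and the two compounds still cannot be told apart on this read-out. For the compounds shown here, this is also the first measured change at this position, since the only earlier step concerned an aromatic nitrogen.

Nothing available here explains why the number holds with sulfo in place. This single pair also leaves open whether another group on the same oxygen, such as an acetyl group or a phosphono group, would likewise leave the number within the scatter or would move it clearly.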